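A few compounds are considered here, and "the series" means these few. Any claim that something is new, unique, unknown or untested is made for them only; others in the source may bear on it.

Measured so far:
compound 1 `Fc1cc(Nc2cc(Nc3ccc(Cl)cc3)ncn2)ccc1Oc1ccncc1-c1cccnc1` — 1610 nM
compound 2 `Fc1cc(Nc2cc(Nc3cccc(Cl)c3)ncn2)ccc1Oc1ccncc1-c1cccnc1` — 180 nM

In a functional assay on A549 cells (Homo sapiens) for cytotoxicity, read by MTT assay, with a stated time of 72 h (on this read-out lower numbers stand for stronger inhibition and higher numbers for weaker inhibition), compound 1 gives 1610 nM and compound 2 gives 180 nM. Within the data shown here, compound 2 stands with the lower of the two numbers; the step of an 8.9-fold lower number from compound 1 to compound 2 (0.95 log units; beyond the scatter) separates it from compound 1, its only neighbour on this read-out.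

Compound 3 `COc1cc(Nc2cc(Nc3ccc(Oc4ccncc4-c4cccnc4)c(F)c3)ncn2)cc(OC)c1` has not been measured. It differs from compound 2 in one place: 3,5-dimethoxyphenyl in place of 3-chlorophenyl on a nitrogen on an aromatic ring. Neither measured step bears directly on this change. The only step shown, an 8.9-fold lower number from compound 1 to compound 2 (0.95 log units; beyond the scatter), moves a chlorine around the same ring and says nothing about replacing the chloro group by two methoxy groups, so the direction of the change for compound 3 is uncertain. A small step from compound 2 is expected, a 1.9-fold higher number from compound 2 to compound 3 (0.29 log units; within the scatter), with a slight lean toward a higher number. Compound 3 is therefore estimated at 350 nM, between 80 nM and 1500 nM.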

Compound 3, half-maximal inhibitory concentration: 560 nM
Estimate against measurement, compound 3: 1.6-fold (0.20 log units) below; measured number inside the range.
By their numbers in this assay, from the lowest: compound 2; then compound 3; then compound 1.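

In this assay, the step of a 3.1-fold higher number from compound 2 to compound 3 (0.49 log units; beyond the scatter) shows that a phenyl ring on this nitrogen can carry two methoxy groups and no chlorine, yet the change from 3-chlorophenyl to 3,5-dimethoxyphenyl costs a measurable amount. The comparison with the 4-chlorophenyl group runs the other way, with a 2.9-fold lower number from compound 1 to compound 3 (0.46 log units; beyond the scatter) in the same assay, so the 3,5-dimethoxyphenyl group places compound 3 on the lower side of compound 1 and on the higher side of compound 2. Nothing shown here explains either step.

The compounds shown leave open whether a phenyl ring with a single methoxy group would behave like 3-chlorophenyl or like 3,5-dimethoxyphenyl. They also leave open what a ring bearing an amine or a carboxylic acid would give on this nitrogen.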